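Urea aryl swap on a pyrazole series at low concentration

A few compounds are considered here, and "the series" means these few. Any claim that something is new, unique, unknown or untested is made for them only; others in the source may bear on it.

Measured compounds:
compound 1 `COc1cc(Cl)cc(-c2nn(-c3cccc(NC(=O)Nc4ccc(Cl)c(C(F)(F)F)c4)c3)cc2-c2ccncc2)c1`, 97%
compound 2 `COc1cc(Cl)cc(-c2nn(-c3cccc(NC(=O)Nc4cc(C(F)(F)F)cc(C(F)(F)F)c4)c3)cc2-c2ccncc2)c1`, 96%
compound 3 `COc1cc(Cl)cc(-c2nn(-c3cccc(NC(=O)Nc4ccc(Cl)c(Cl)c4)c3)cc2-c2ccncc2)c1`, 97%

Three compounds share one core and differ only in the aryl group on the far end of the urea. In a functional assay on M14 cells (Homo sapiens) for inhibition, read by sulforhodamine B assay, with a stated time of 48 h, tested at 0.01 uM (a higher number here means a weaker effect of the compound at the concentration tested, a lower number a stronger effect), compound 1 gives 97%, compound 2 gives 96%, and compound 3 gives 97%. Compound 3 stands level with compound 1 and together they hold the highest numbers of the three; the number of compound 2 lies within the scatter of both. In plain terms, none of the three shows a clear effect at the concentration tested.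

Within the data shown here, the one single-place step among them, no change at the digits printed from compound 1 to compound 3 (within the scatter), changed nothing beyond the scatter.

Compound 4 `COc1cc(Cl)cc(-c2nn(-c3cccc(NC(=O)Nc4cccc(C(F)(F)F)c4)c3)cc2-c2ccncc2)c1` is not yet measured. It differs from compound 3 as follows: 3-(trifluoromethyl)phenyl in place of 3,4-dichlorophenyl on an amide-type nitrogen. This is a change at the same urea aryl group that was varied among compounds 1, 2 and 3 without any visible consequence in this assay. Among the measured compounds shown here, the only step that bears on it, from compound 1 to compound 3, was flat, so no step beyond the scatter is expected here either; the step from compound 3 to compound 4 is estimated as a number 1 percentage points lower from compound 3 to compound 4 (within the scatter). Compound 4 is therefore expected to give about 96%, between 88% and 102%.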

Compound 4, a percentage reported as activity, at one concentration (the size of the read-out at that concentration, not a potency): 98%
Compound 4: the middle estimate sits 2 percentage points below what was measured; low and high end bracket the measured number.
By their numbers in this assay, from the lowest: compounds 2, 1, 3 and 4 (each within the scatter of the next).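

In this assay, among these compounds, the earlier compounds only exchanged one set of substituents for another on the aryl group at the far end of the urea, whereas compound 4 shows what happens when that ring carries less: hydrogen in place of chloro gives a number 1 percentage points higher from compound 1 to compound 4 (within the scatter) and hydrogen in place of trifluoromethyl gives a number 2 percentage points higher from compound 2 to compound 4 (within the scatter). Among the compounds shown here, putting 3-(trifluoromethyl)phenyl in place of 3,4-dichlorophenyl on the amide-type nitrogen gives a number 1 percentage points higher from compound 3 to compound 4 (within the scatter), so the flat picture now spans four aryl groups, though it says only that none of these changes brought out a clear effect at this one low concentration, not that the group is unimportant. No other information is available that bears on this result.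

Groups of a different kind on that ring, such as a carboxylic acid or a dimethylamino group, remain open, as do changes elsewhere on the shared core. Going by these compounds, whether these aryl groups differ at all also remains open, as that could only be told at a concentration where the compounds give a clear effect.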